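The source may report more compounds than this note shows. Statements on the series, on what has been measured and on what is new or still open speak of the compounds shown alone.

Measured so far in a physicochemical assay for solubility, with a stated time of 24 h (on this read-out higher numbers stand for higher solubility and lower numbers for lower solubility), as follows
Compound 1 `Cc1ccc([C@@H](C)Oc2cc3onc(CCC(=O)O)c3cc2Cl)nc1` gives > 860 ug/mL as a limit
Compound 2 `O=C(O)CCn1c(=O)oc2cc(OCC3CC3)c(Cl)cc21` gives > 2060 ug/mL as a limit

Compound 1 stands at > 860 ug/mL in this assay and this is a limit, not an exact number. Compound 3 `C[C@@H](Oc1cc2onc(CCC(=O)O)c2cc1Cl)c1ccc(Cl)cn1` differs from it by one change chloro in place of methyl on an aromatic carbon in which chloro replaces methyl on an aromatic carbon, turning 5-methylpyridin-2-yl into 5-chloropyridin-2-yl. Within the data shown here, no measured pair shows a comparable single change. The expected step that the limit leaves unreadable from compound 1 to compound 3 is estimated to be none beyond the usual scatter. Compound 3 is expected at 900 ug/mL with an estimated range from 400 ug/mL to 1800 ug/mL in this measurement.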

Compound 3, solubility: > 620 ug/mL
Compound 3: no number, only a limit; the forecaster's own chance of this, stated with the estimate: 65%; the middle value does not contradict the limit.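

Among these compounds, compound 1 and compound 3 both give only limits in this assay, so no step between them can be read. The compounds shown leave open whether chloro in place of methyl shifts the read-out at all.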